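This account rests on a few compounds, and the source may have more. Where it says the series, first, only, none or still open, it means among the compounds named here.

Compound 3 `COc1ccc(/C=N/NC(=O)c2cccnc2Nc2cccc(C(F)(F)F)c2)cc1OC` in a functional assay on the whole organism (strain Wistar) for inhibition, with Rattus norvegicus as the target, read by paw edema, with a stated time of 30 min, at a dose of 10 mg/kg by the intraperitoneal route (on this read-out lower numbers stand for less inhibition and higher numbers for more inhibition at the one dose given (going by the name of the read-out)), gives 60.1%, the top number of the three measured. Compound 2 `O=C(N/N=C/c1ccc(Cl)cc1)c1cccnc1Nc1cccc(C(F)(F)F)c1` gives 52.4% in this assay, and the step of a number 7.7 percentage points higher from compound 2 to compound 3 (within the scatter) stays within the scatter, so the two are not separable. Compound 1 `O=C(N/N=C/c1ccc(F)cc1)c1cccnc1Nc1cccc(C(F)(F)F)c1` gives 33.9% in this assay, and a number 26.2 percentage points higher from compound 1 to compound 3 (beyond the scatter) is beyond the scatter, as is a number 18.5 percentage points higher from compound 1 to compound 2 (beyond the scatter).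

Compound 4 `O=C(N/N=C/c1cccnc1)c1cccnc1Nc1cccc(C(F)(F)F)c1` differs from compound 3 at the carbon with a double bond to nitrogen: pyridin-3-yl in place of 3,4-dimethoxyphenyl on a carbon with a double bond to nitrogen. Among the compounds with values here, the steps 1>3 and 2>3 also exchanged the aryl on that carbon, both upward, modest in size; no measured compound carries pyridin-3-yl there, so the change has no direct precedent. An estimated step of a number 15.1 percentage points lower from compound 3 to compound 4 (beyond the scatter) downward is expected for compound 4, in this assay estimated at 45%, within 25% to 65%.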

Compound 4, a percentage reported as inhibition, in the whole organism at one dose (the size of the read-out at that dose, not a potency): 59.1%
Compound 4: middle estimate off by 14.1 percentage points, on the low side, and the stated range covers the measured number.
By their numbers in this assay, from the lowest: compound 1; then compounds 2, 4 and 3 (each within the scatter of the next).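

In this assay, the carbon with a double bond to nitrogen accepts a ring with a hetero atom as well as a dimethoxylated phenyl ring: a number 1 percentage points lower from compound 3 to compound 4 (within the scatter). Pyridin-3-yl in place of 4-chlorophenyl gives a number 6.7 percentage points higher from compound 2 to compound 4 (within the scatter), while in place of 4-fluorophenyl it gives a number 25.2 percentage points higher from compound 1 to compound 4 (beyond the scatter), which leaves compound 1 as the only one of the four set apart from the others. Nothing at hand bears on the reason for this result.

Still open, on these data alone, is whether a saturated amine such as piperidin-4-yl, or a phenyl ring carrying a carboxylic acid, would hold this level on that carbon. A single dose also leaves the relation between dose and response open.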